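Replacing an Aminoethyl Amide with an Ethoxyphenyl Amide

This account rests on a few compounds, and the source may have more. Where it says the series, first, only, none or still open, it means among the compounds named here.

Measured compounds:
Compound 1, `CCn1c(C(=O)NCCN)ccc1C(CC)(CC)c1ccc(OCC(=O)C(C)(C)C)c(C)c1`: 120 nM
Compound 2, `CCn1c(C(=O)NCCCN(C)C)ccc1C(CC)(CC)c1ccc(OCC(O)C(C)(C)C)c(C)c1`: 37 nM
Compound 3, `CCn1c(C(=O)NCC(OC)OC)ccc1C(CC)(CC)c1ccc(OCC(O)C(C)(C)C)c(C)c1`: 150 nM

All three were tested in an assay on HL-60 cells for agonist activity at vitamin D3 receptor (Homo sapiens), read by microscopy, with a stated time of 96 h; on this read-out lower numbers stand for an effect already at smaller amounts and higher numbers for an effect only at larger amounts of compound. Compound 1 sits close to compound 3, while compound 2 gives a clearly lower number than compound 1. Among the compounds with values here, the only single-point step among them, a 4.1-fold higher number from compound 2 to compound 3 (0.61 log units; beyond the scatter), concerns the chain on the amide-type nitrogen. Compound 4, `CCOc1ccc(NC(=O)c2ccc(C(CC)(CC)c3ccc(OCC(=O)C(C)(C)C)c(C)c3)n2CC)cc1`, differs from compound 1 at that same nitrogen: 4-ethoxyphenyl in place of 2-aminoethyl on an amide-type nitrogen. Compound 1 and compound 3, both differing from compound 2 at this nitrogen, give neighbouring numbers, so a change here is expected to move the number only modestly, if at all, toward higher values. Compound 4 is therefore expected at 200 nM, between 60 nM and 700 nM, a step of a 1.7-fold higher number from compound 1 to compound 4 (0.22 log units; within the scatter).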

Compound 4, half-maximal effective concentration: > 50000 nM
Compound 4: a limit, no number; the forecaster's own chance of this, stated with the estimate: 10%; middle value at least 250-fold (2.39 log units) from the limit.
By their numbers in this assay, from the lowest: compound 2; then compounds 1 and 3 (each within the scatter of the next). At a limit, above all of these: compound 4.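

In this assay, the amide-type nitrogen proves far from indifferent to what it carries: 4-ethoxyphenyl in place of 2-aminoethyl gives an at least 410-fold higher number from compound 1 to compound 4 (2.61 log units; beyond the scatter). Compound 4 stands at a limit of the assay and not at a number: the limit of > 50000 nM in this assay, at which 1 of the 4 values shown sits. Of the groups shown on this nitrogen, 4-ethoxyphenyl alone brings an aromatic ring, while the open chains of compound 1, compound 2 and compound 3 all give numbers. Still open, as far as these compounds go, is whether the drop follows from the ring itself or from its ethoxy group, and whether a plain phenyl or a 4-aminophenyl on this nitrogen would behave alike.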